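A few compounds are considered here, and "the series" means these few. Any claim that something is new, unique, unknown or untested is made for them only; others in the source may bear on it.

In a functional assay (aorta) with Oryctolagus cuniculus as the target (a lower number here means tighter binding, a higher number weaker binding), compound 3 `Fc1ccc(C(c2ccc(F)cc2)C2CCN(CCCOc3cccc4ccccc34)CC2)cc1` gives 5.01 nM, the middle of the three numbers. Compound 2 `CC(C)(C)c1ccc(OCCCN2CCC(C(c3ccc(F)cc3)c3ccc(F)cc3)CC2)cc1` lies lower at 1 nM, and compound 1 `COc1cc(C(=O)O)ccc1OCCCN1CCC(C(c2ccc(F)cc2)c2ccc(F)cc2)CC1` lies higher at 79.4 nM. Compound 4 `Fc1ccc(C(c2ccc(F)cc2)C2CCN(CCCOc3ccc4ccccc4c3)CC2)cc1` keeps the shared core and differs only on the oxygen: naphthalen-2-yl in place of naphthalen-1-yl on an oxygen on a saturated carbon. Within the data shown here, no measured pair tests this swap directly. Among the measured compounds shown here, the nearest precedent, a 5.0-fold higher number from compound 2 to compound 3 (0.70 log units; beyond the scatter), exchanged 4-(tert-butyl)phenyl for naphthalen-1-yl and was modest. The large steps, a 79-fold lower number from compound 1 to compound 2 (1.90 log units; beyond the scatter) and a 16-fold lower number from compound 1 to compound 3 (1.20 log units; beyond the scatter), both replaced 4-carboxy-2-methoxyphenyl, a less similar change. In this assay, a shift smaller than the modest step is therefore expected, probably none beyond the scatter. The estimated step is a 1.3-fold lower number from compound 3 to compound 4 (0.10 log units; within the scatter). Compound 4 is expected at 4 nM, within an estimated range of 1.3 nM to 13 nM.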

Compound 4, dissociation constant: 7.94 nM
The estimate for compound 4 lay 2.0-fold (0.30 log units) below the measured number; the measured number falls inside the stated range.
By their numbers in this assay, from the lowest: compound 2; then compounds 3 and 4 (each within the scatter of the next); then compound 1.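

In this assay, naphthalen-2-yl in place of naphthalen-1-yl on the oxygen gives a 1.6-fold higher number from compound 3 to compound 4 (0.20 log units; within the scatter), so the result does not separate these two attachments of the same ring system. Compound 4 still differs clearly from the other two groups, with a 7.9-fold higher number from compound 2 to compound 4 (0.90 log units; beyond the scatter) and a 10-fold lower number from compound 1 to compound 4 (1.00 log units; beyond the scatter), on the same sides as compound 3. No evidence is available to explain these differences. Going by these compounds, what remains open is how an amine on the naphthalen-2-yl group, or a longer chain on the oxygen, would change the number.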